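The source may hold more compounds than are shown below. What is called first, only, known or untested is meant among the compounds shown, and "the series" means these compounds.

In an ADME assay on CCRF-HSB-2 cells (Homo sapiens) for cytotoxicity, with a stated time of 7 days (on this read-out lower numbers stand for higher toxicity in this test and higher numbers for lower toxicity in this test), compound 1 `Nc1nc(OCc2ccccc2)c2ncn(/C=C3/CC3(CO)CO)c2n1` reaches only the limit > 20000 nM. Compound 2 `Nc1nc(N2CCCC2)c2ncn(/C=C3/CC3(CO)CO)c2n1` likewise gives the limit > 20000 nM. Compound 3 `CCCCCCSc1nc(N)nc2c1ncn2/C=C1/CC1(CO)CO` gives 60000 nM.

Compound 3 thus holds the only real number among these three results; the other two are limits. Compound 4 `Nc1nc(SCc2ccccc2)c2ncn(/C=C3/CC3(CO)CO)c2n1` differs from compound 3 by phenyl in place of pentyl on a saturated chain carbon bound to a sulfur. The measured steps that reach compound 3 are a step that the limit leaves unreadable from compound 1 to compound 3 and a step that the limit leaves unreadable from compound 2 to compound 3, both of unreadable size because of the limit of > 20000 nM in this assay, at which 2 of the 3 values shown sit. No measured change of a chain into a ring exists here, so in this assay no step beyond the usual scatter is expected from this change. Compound 4 is therefore estimated at 45000 nM, between 15000 nM and 120000 nM, an expected step of a 1.3-fold lower number from compound 3 to compound 4 (0.12 log units; within the scatter).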

Compound 4, half-maximal cytotoxic concentration: > 100000 nM
Compound 4 was reported as a limit; the forecaster's own chance of this, stated with the estimate: 35%; middle value at least 2.2-fold (0.34 log units) away from the limit.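

In this assay, for the compounds shown here, phenyl in place of pentyl on a saturated chain carbon bound to a sulfur gives the first readable step at this position: an at least 1.6-fold higher number from compound 3 to compound 4 (0.22 log units; that floor lies within the scatter). Compound 4 is reported only as a limit, so the full size of this step stays unknown: the limit of > 100000 nM in this assay, at which 1 of the 4 values shown sits.
The steps from compound 1 and from compound 2 to compound 4 cannot be read: the limit of > 20000 nM in this assay, at which 2 of the 4 values shown sit.

The compounds shown leave open how a methyl group or a chain ending in a carboxylic acid, in place of hexyl, would read in this assay.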